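Swapping a trifluoromethyl for piperidine on an aryl ketone

The source may hold more compounds than are shown below. What is called first, only, known or untested is meant among the compounds shown, and "the series" means these compounds.

Compound 1 `O=C(CCCCCCC(=O)c1ccc2ccccc2c1)NO`: 35 nM
Compound 2 `O=C(CCCCCCCC(=O)c1ccc(C(F)(F)F)cc1)NO`: 45 nM

In an assay on isolated protein for inhibition of histone deacetylase 8 (Homo sapiens) (on this read-out higher numbers stand for weaker inhibition and lower numbers for stronger inhibition), compound 1 gives 35 nM and compound 2 gives 45 nM; the two numbers lie within the usual scatter of each other, so neither stands apart. Compound 3 `O=C(CCCCCCCC(=O)c1ccc(N2CCCCC2)cc1)NO` is not yet measured. It differs from compound 2 by piperidin-1-yl in place of trifluoromethyl on an aromatic carbon. No comparable swap has been measured here, so there is no basis for a directional expectation; the step is expected to be a 1.3-fold higher number from compound 2 to compound 3 (0.12 log units; within the scatter), no more than the scatter allows. Compound 3 is expected to give about 60 nM in this assay, between 20 nM and 200 nM.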

Compound 3, half-maximal inhibitory concentration: 9.5 nM
The estimate for compound 3 lay 6.3-fold (0.80 log units) above the measured number, and the stated range ends above it.
By their numbers in this assay, from the lowest: compound 3; then compounds 1 and 2 (each within the scatter of the next).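

This aromatic carbon is sensitive to what it carries: in this assay, piperidin-1-yl in place of trifluoromethyl gives a 4.7-fold lower number from compound 2 to compound 3 (0.68 log units; beyond the scatter), a modest step but one beyond the scatter. The position therefore accepts a larger group containing a ring and a nitrogen, and the number falls rather than rises. Nothing available here explains the step.

Still open, from the compounds shown here alone, is whether the ring or the nitrogen matters: cyclohexyl, morpholine or an open-chain dimethylamino group at this carbon would help separate them. It is also unknown whether the same swap would have a similar effect on the core of compound 1.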